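Replacing a Cyanophenyl Amide with a Thiophene Amide

The compounds below may be only part of what the source reports. "The series", "measured", "known", "first", "only" and "open" are said of these compounds alone.

Compound 1, `N#Cc1ccc(C(=O)NC(=S)N2CCc3c(OCCCCCOc4ccc(Cl)cc4)cccc32)cc1`: in an ADME assay on Huh-7 cells (Homo sapiens) for cytotoxicity (a higher number here means that more compound is tolerated, a lower number that less compound is tolerated), compound 1 gives > 50000 nM, which is a limit of the assay and not a number.
Compound 2, `CC(C)(C)c1ccc(C(=O)NC(=S)N2CCc3c(OCCCCCOc4ccc(Cl)cc4)cccc32)cc1`: compound 2 gives > 50000 nM, again a limit of the assay.
Compound 3, `O=C(NC(=S)N1CCc2c(OCCCCCOc3ccc(Cl)cc3)cccc21)C1CCCCC1`: compound 3 gives > 50000 nM, also a limit of the assay.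

All three compounds share one core and differ only in the group attached to the carbonyl carbon of the acylthiourea. None of them produced a readable number in this assay; every value sits at the limit of > 50000 nM in this assay, at which 3 of the 3 values shown sit. Compound 1 therefore stands at that limit, with no number of its own. The measured steps give no size: the step that the two limits leave unreadable from compound 1 to compound 2, the step that the two limits leave unreadable from compound 1 to compound 3 and the step that the two limits leave unreadable from compound 2 to compound 3 are all unreadable, since each joins two limits.

Compound 4, `O=C(NC(=S)N1CCc2c(OCCCCCOc3ccc(Cl)cc3)cccc21)c1ccsc1`, carries the change (thiophen-3-yl in place of 4-cyanophenyl on a carbonyl carbon). The three measured steps, all unreadable, give no direction to expect, so no step beyond the scatter is expected; the expected step is a number no higher from compound 1 to compound 4 (the limit leaves the size open). For compound 4 the estimate in this assay is 50000 nM, within a range from 20000 nM to 100000 nM, and the result is most likely to be reported again only as a limit.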

Compound 4, half-maximal cytotoxic concentration: > 50000 nM
Compound 4 gave a limit, no number; the forecaster's own chance of this, stated with the estimate: 85%; the middle value lies on the limit itself.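

In this assay compound 4 gives > 50000 nM, a limit of the assay and not a number. Its steps from compound 1, compound 2 and compound 3 cannot be read, since each joins two limits: the limit of > 50000 nM in this assay, at which 4 of the 4 values shown sit. The compounds shown leave open whether the group on the carbonyl carbon affects how much compound Huh-7 cells tolerate.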